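The compounds below may be only part of what the source reports. "The series", "measured", "known", "first", "only" and "open" are said of these compounds alone.

Compound 1 `CC(C)CNC(=N)NC(=N)Nc1ccc(F)cc1F`: 19800 nM
Compound 2 `CC(C)NC(=N)NC(=N)Nc1ccc(C(F)(F)F)cc1`: 3200 nM
Compound 3 `CC(C)NC(=N)NC(=N)Nc1ccc(F)c(F)c1`: 26000 nM

In a functional assay on A2780 cells (Homo sapiens) for antiproliferative activity, read by MTT assay, with a stated time of 72 h (on this read-out lower numbers stand for stronger inhibition and higher numbers for weaker inhibition), compound 1 lies within the scatter of compound 3, while compound 2 carries a lower number, beyond the scatter. Compound 4 `N=C(NC(=N)NC1CCCC1)Nc1ccc(F)cc1F` keeps the core of compound 1 and has cyclopentyl in place of isobutyl on an amine nitrogen. Among the compounds with values here, no measured pair isolates this change, so the expectation in this assay is anchored on compound 1 at 19800 nM and remains uncertain. A modest move towards a lower number is expected, hardly beyond the scatter. The estimated outcome is a 1.7-fold lower number from compound 1 to compound 4 (0.22 log units; within the scatter) and would be a small step. For compound 4 the estimate is 12000 nM, with an expected range from 5000 nM to 28000 nM in this read-out.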

Compound 4, half-maximal inhibitory concentration: 14700 nM
Estimate against measurement, compound 4: 1.2-fold (0.09 log units) below, and the stated range covers the measured number.
By their numbers in this assay, from the lowest: compound 2; then compounds 4, 1 and 3 (each within the scatter of the next).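

Within the data shown here, this is the first step that changes only the group on this amine nitrogen: in this assay, cyclopentyl in place of isobutyl gives a 1.3-fold lower number from compound 1 to compound 4 (0.13 log units; within the scatter). On the core of compound 1, this position therefore accepts a five-membered ring of carbon in place of the open isobutyl group with no difference that can be told from the scatter. Nothing at hand accounts for this result. On these data alone, whether a longer chain, a phenyl group or a carboxylic acid on this nitrogen would move the number beyond the scatter remains open.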